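The source may report more compounds than this note shows. Statements on the series, on what has been measured and on what is new or still open speak of the compounds shown alone.

In a functional assay on CHO cells for agonist activity at Free fatty acid receptor 1 (Homo sapiens), read by reporter gene assay (a lower number here means a smaller maximal response, a higher number a larger maximal response), three compounds have been measured:

Compound 1 `O=C(O)CCc1ccc(NCc2ccc(Cl)cc2)cc1` gives 111%.
Compound 2 `O=C(O)CCc1ccc(NCc2ccc(Cl)c(Cl)c2)cc1` gives 117%.
Compound 3 `O=C(O)CCc1ccc(NCc2ccc3ccccc3c2)cc1` gives 123%.

Compound 1 stands lowest of the three: compound 2 lies a number 6 percentage points higher from compound 1 to compound 2 (within the scatter), while compound 3 lies beyond the scatter above it. Compound 4 `CN(C)Cc1ccc(CNc2ccc(CCC(=O)O)cc2)cc1` is built from compound 1 by one change: (dimethylamino)methyl in place of chloro on an aromatic carbon. Within the data shown here, no measured step swaps one group for another at this position; the only known step, chloro in place of hydrogen, moved the response from compound 1 to compound 2 within the scatter. Since all three measured compounds sit close together, no step beyond the scatter is expected for compound 4, whose estimated response is 110% with a range of 92% to 128%, an expected step of a number 1 percentage points lower from compound 1 to compound 4 (within the scatter).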

Compound 4, largest response reached (reported as percent of maximum), in percent of the reference or control that the assay uses: 12%
The estimate for compound 4 lay 98 percentage points above the measured number, outside the stated range (below it).
By their numbers in this assay, from the lowest: compound 4; then compounds 1, 2 and 3 (each within the scatter of the next, the first and the last beyond it).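

Replacing chloro with (dimethylamino)methyl gives a number 99 percentage points lower from compound 1 to compound 4 (beyond the scatter) in this assay, so the maximal response depends strongly on what occupies this place on the ring, para to a large group. The earlier compounds shown here gave no sign of a drop this large, and compound 4 shows that this place does not accept every group. No measurement shown gives a reason for this loss.

As far as these compounds go, it remains open whether the amine nitrogen or the larger group drives the drop. A tert-butyl group, of similar size without nitrogen, or a smaller aminomethyl group at the same place would help separate the two.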